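The source may report more compounds than this note shows. Statements on the series, on what has been measured and on what is new or still open speak of the compounds shown alone.

In a functional assay on cells (T-cell, Mus musculus, strain BALB/c) for inhibition, read by MTT assay, with stated times of 24 h and 72 h (on this read-out higher numbers stand for weaker inhibition and lower numbers for stronger inhibition), compound 3 `COc1cc(-c2nnc(SCc3c(F)cccc3F)o2)ccc1O` gives 10100 nM, the highest of the three numbers seen so far. Compound 1 `COc1cc(-c2nnc(SCc3ccc(C)cc3)o2)ccc1O` gives 6210 nM and compound 2 `COc1cc(-c2nnc(SCc3ccccc3F)o2)ccc1O` gives 5790 nM, and neither of those differs beyond the scatter, as a 1.6-fold higher number from compound 1 to compound 3 (0.21 log units; within the scatter) and a 1.7-fold higher number from compound 2 to compound 3 (0.24 log units; within the scatter) show. Compound 4 `COc1cc(-c2nnc(SCc3ccc(F)cc3F)o2)ccc1O` differs from compound 3 in one place: 2,4-difluorophenyl in place of 2,6-difluorophenyl on a saturated chain carbon bound to a sulfur The measured steps that bear on this part of the molecule, a 1.1-fold lower number from compound 1 to compound 2 (0.03 log units; within the scatter) and a 1.7-fold higher number from compound 2 to compound 3 (0.24 log units; within the scatter), were both within the scatter, and nothing among the three compounds separates one pattern of fluorines from another. No step beyond the scatter is therefore expected in this assay. Compound 4 is estimated at 7500 nM, between 3500 nM and 16000 nM, which corresponds to an expected step of a 1.3-fold lower number from compound 3 to compound 4 (0.13 log units; within the scatter).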

Compound 4, half-maximal inhibitory concentration: 9690 nM
For compound 4 the middle estimate is 1.3-fold (0.11 log units) below the measured one; measured number inside the range.
By their numbers in this assay, from the lowest: compounds 2, 1, 4 and 3 (each within the scatter of the next).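

In this assay, 2,4-difluorophenyl in place of 2,6-difluorophenyl gives a 1.0-fold lower number from compound 3 to compound 4 (0.02 log units; within the scatter), so this new fluorine pattern is not separated from the earlier one. The other two steps, a 1.7-fold higher number from compound 2 to compound 4 (0.22 log units; within the scatter) and a 1.6-fold higher number from compound 1 to compound 4 (0.19 log units; within the scatter), also stay within the scatter, and all four groups on the saturated chain carbon bound to a sulfur remain indistinguishable in this read-out. Nothing presented explains this lack of separation. The compounds shown leave open whether an amine, a carboxylic acid or a longer chain at this place would give a step beyond the scatter.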